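The source may hold more compounds than are shown below. What is called first, only, known or untested is meant among the compounds shown, and "the series" means these compounds.

In a functional assay on MDA-MB-231 cells (Homo sapiens) for antiproliferative activity, read by MTT assay, with a stated time of 48 h (a lower number here means a stronger inhibitor, a higher number a weaker inhibitor), compound 1, with structure `Cc1ccc2nc(Nc3nc(Nc4ccc(S(N)(=O)=O)cc4)ncc3F)sc2c1`, gives 6390 nM. Compound 2, with structure `COc1ccc2nc(Nc3nc(Nc4ccc(S(N)(=O)=O)cc4)ncc3C)sc2c1`, reaches only the limit of this assay in that measurement, and for compound 2 the reading is > 50000 nM, a limit rather than a number. This is the limit of > 50000 nM in this assay, at which 1 of the 2 values shown sits, so where compound 2 truly stands on the scale is not known, only that it sits at the weak end. The step to compound 3, whose structure is `COc1ccc2nc(Nc3nc(Nc4ccc(S(N)(=O)=O)cc4)ncc3F)sc2c1`, brings (fluoro in place of methyl on an aromatic carbon); in words, fluoro in place of methyl on an aromatic carbon. Within the data shown here, no measured step between two compounds shows what this exchange does here, and the comparison of compound 1 with compound 2 does not isolate it. The step from compound 2 to compound 3 in this assay is therefore expected to be downward in number, that is toward stronger inhibition, but of uncertain size, expected as an at least 4.1-fold lower number from compound 2 to compound 3 (0.61 log units; beyond the scatter). Compound 3 is expected to give about 12000 nM, within a range from 3000 nM to 50000 nM.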

Compound 3, half-maximal inhibitory concentration: 26600 nM
The estimate for compound 3 lay 2.2-fold (0.35 log units) below the measured number; measured number inside the range.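

In this assay compound 2 gives > 50000 nM as a limit and not a number. Fluoro in place of methyl on an aromatic carbon therefore reads only as an at least 1.8-fold lower number from compound 2 to compound 3 (0.27 log units; that floor lies within the scatter) and no more firmly than that, so this position, ortho to a large group and para to a large group, shows no effect of the exchange that is certain to exceed the scatter. With fluoro held fixed, methoxy in place of methyl elsewhere on the shared core gives a 4.2-fold higher number from compound 1 to compound 3 (0.62 log units; beyond the scatter) in this assay as a step with a true size.

Going by these compounds, how far compound 2 really lies from compound 3 stays open: only a limit is known for it. Also open, on these data alone, is what a chlorine atom, a nitrile or an amine would do at this position.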